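The source may hold more compounds than are shown below. What is called first, only, known or untested is meant among the compounds shown, and "the series" means these compounds.

Of the compounds shown here, three sharing one core have been measured in a functional assay on MCF7 cells (Homo sapiens) for antiproliferative activity, read by MTT assay, with a stated time of 48 h; a lower number here means a stronger inhibitor of growth, a higher number a weaker inhibitor of growth. Compound 1 `CCOc1cc(NC(=O)CCCCCNC(=O)CCCc2ccccc2)cc2c1OCC([N+](=O)[O-])=C2` gives 5960 nM, compound 2 `CCOc1cc(NC(=O)CCCCCCC(=O)Nc2cc(-c3ccc(C)s3)ccc2N)cc2c1OCC([N+](=O)[O-])=C2` gives 5330 nM, and compound 3 `CCOc1cc(NC(=O)CCCCCCC(=O)Nc2ccccc2N)cc2c1OCC([N+](=O)[O-])=C2` gives 13500 nM. Compound 3 thus stands highest of the three numbers, weaker than both companions: a 2.3-fold higher number from compound 1 to compound 3 (0.36 log units; beyond the scatter) and a 2.5-fold higher number from compound 2 to compound 3 (0.40 log units; beyond the scatter).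

Compound 4 `CCOc1cc(NC(=O)CCCCCCC(=O)Nc2cc(-c3ccccc3)ccc2N)cc2c1OCC([N+](=O)[O-])=C2` has not yet been measured. It differs from compound 3 in one place: phenyl in place of hydrogen on an aromatic carbon. Going by the values given here, the step that bears on this is the one between compound 2 and compound 3, where removing an aromatic ring from that same carbon gave a 2.5-fold higher number from compound 2 to compound 3 (0.40 log units; beyond the scatter). Putting an aromatic ring back on that carbon, here a phenyl rather than a methylthiophene, is therefore expected to move the number in the opposite direction, by a modest amount of about the same size, though a phenyl is a different ring and the match need not be exact.

In this assay compound 4 is expected to give about 5500 nM, within a range of 2500 nM to 12000 nM, which would be a step of a 2.5-fold lower number from compound 3 to compound 4 (0.39 log units; beyond the scatter).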

Compound 4, concentration for 50% growth inhibition: 9370 nM
Compound 4: middle estimate off by 1.7-fold (0.23 log units), on the low side, within the range that was stated.
By their numbers in this assay, from the lowest: compounds 2, 1, 4 and 3 (each within the scatter of the next, the first and the last beyond it).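

In this assay, phenyl in place of hydrogen on this aromatic carbon, para to the amino group, gives a 1.4-fold lower number from compound 3 to compound 4 (0.16 log units; within the scatter) and so brings no clear gain, which shows that not every aromatic ring here repeats the step seen with 5-methylthiophen-2-yl. That earlier ring gives a 2.5-fold higher number from compound 2 to compound 3 (0.40 log units; beyond the scatter) when hydrogen replaces it, yet phenyl in place of 5-methylthiophen-2-yl gives a 1.8-fold higher number from compound 2 to compound 4 (0.25 log units; within the scatter) and leaves the two rings unresolved from each other. No accompanying measurement explains these results.

As far as these compounds go, it remains open whether plain thiophen-2-yl, without its methyl group, or pyridin-3-yl would behave like phenyl or like 5-methylthiophen-2-yl on this carbon. From the compounds shown here alone, it also remains open whether a methyl group or a fluorine atom there would differ from hydrogen at all.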